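Swapping the Amine Arm on a Sulfamate Inhibitor

The source may hold more compounds than are shown below. What is called first, only, known or untested is meant among the compounds shown, and "the series" means these compounds.

Measured compounds:
compound 1 `CCN(Cc1ccccn1)c1ccc(C(=O)N2CCc3ccc(OS(N)(=O)=O)cc3C2)cc1` gives 42.5%
compound 2 `CCN(Cc1ccc(F)cc1)c1cccc(C(=O)N2CCc3ccc(OS(N)(=O)=O)cc3C2)c1` gives 10.9%

Both were tested in an assay on HEK293 cells for inhibition of Steryl-sulfatase (Homo sapiens), tested at 0.1 uM; a lower number here means a weaker effect, a higher number a stronger effect of the compound at the concentration tested. Within the data shown here, compound 2, with 10.9%, stands lowest of the two numbers; compound 1 lies higher by a gap that is beyond the usual scatter, and since the two compounds differ in more than one place, their values show only that the pair spans a wide range.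

Compound 3 `CN(CCN1CCCCC1)c1cccc(C(=O)N2CCc3ccc(OS(N)(=O)=O)cc3C2)c1` has not yet been measured. It differs from compound 2 in one place: methyl(2-(piperidin-1-yl)ethyl)amino in place of ethyl(4-fluorobenzyl)amino on an aromatic carbon. Among the measured compounds shown here, no measured pair in this set shows a change of this kind, so there is no step to lean on for its size or direction. A modest change is expected, estimated as a number 9.1 percentage points higher from compound 2 to compound 3 (within the scatter), possibly no larger than the scatter. For compound 3 the expected result in this assay is 20%, with a range from 0% to 50%.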

Compound 3, a percentage reported as inhibition, at one concentration (the size of the read-out at that concentration, not a potency): 24.5%
The estimate for compound 3 lay 4.5 percentage points below the measured number; low and high end bracket the measured number.
By their numbers in this assay, from the lowest: compound 2; then compound 3; then compound 1.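

In this assay, putting methyl(2-(piperidin-1-yl)ethyl)amino in place of ethyl(4-fluorobenzyl)amino on this aromatic carbon gives a number 13.6 percentage points higher from compound 2 to compound 3 (beyond the scatter). The result shows that this position responds to the choice of amine arm, and that an arm ending in a piperidine ring gives the stronger effect of these two, though the step is only modest. Nothing available here explains the rise.

This swap changes the ethyl to a methyl, the benzyl link to an ethyl chain and the end ring all at once, so the part of the arm that matters remains unresolved. A morpholine ring at the end of the same chain, or a plain dimethylamino group on the same carbon, would help separate the contribution of the ring from that of the chain.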